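This account rests on a few compounds, and the source may have more. Where it says the series, first, only, none or still open, it means among the compounds named here.

Measured so far in a functional assay on K562 cells (Homo sapiens) for inhibition, read by trypan blue exclusion, with a stated time of 72 h; a higher number here means a weaker inhibitor, a lower number a stronger inhibitor:
- compound 1 `O=c1c(S(=O)(=O)c2ccc(F)cc2F)cc2cnc(Nc3ccc4[nH]ccc4c3)nc2n1C1CCCC1` gives 5000 nM
- compound 2 `O=c1[nH]c2nc(Nc3ccc4[nH]ccc4c3)ncc2cc1S(=O)(=O)c1ccc(F)cc1F` gives 15000 nM
- compound 3 `O=c1c(S(=O)(=O)c2ccc(F)cc2F)cc2cnc(Nc3ccc4[nH]ccc4c3)nc2n1C1CC1` gives 500 nM

Compound 3 has the lowest number of the three, and both gaps to it lie beyond the scatter. Compound 4 `O=c1c(S(=O)(=O)c2ccc(F)cc2F)cc2cnc(Nc3ccc4[nH]ccc4c3)nc2n1CC1CC1` differs from it by one change, cyclopropylmethyl in place of cyclopropyl on an aromatic nitrogen.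

Within the data shown here, three measured steps concern this nitrogen: the modest 10-fold lower number from compound 1 to compound 3 (1.00 log units; beyond the scatter), the large 30-fold lower number from compound 2 to compound 3 (1.48 log units; beyond the scatter) and the modest 3.0-fold higher number from compound 1 to compound 2 (0.48 log units; beyond the scatter). Neither group at this nitrogen in these steps is cyclopropylmethyl, so the evidence is indirect. With the modest 10-fold lower number from compound 1 to compound 3 (1.00 log units; beyond the scatter) as the guide, a modest rise is expected in this assay.

The estimated value for compound 4 is 1500 nM, with an expected range from 400 nM to 6000 nM. This is an expected 3.0-fold higher number from compound 3 to compound 4 (0.48 log units; beyond the scatter).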

Compound 4, half-maximal inhibitory concentration: 1000 nM
For compound 4 the middle estimate is 1.5-fold (0.18 log units) above the measured one; measured number inside the range.
By their numbers in this assay, from the lowest: compounds 3 and 4 (each within the scatter of the next); then compound 1; then compound 2.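

In this assay, a 2.0-fold higher number from compound 3 to compound 4 (0.30 log units; within the scatter) leaves cyclopropylmethyl and cyclopropyl on the aromatic nitrogen unseparated. With a 15-fold lower number from compound 2 to compound 4 (1.18 log units; beyond the scatter) and a 5.0-fold lower number from compound 1 to compound 4 (0.70 log units; beyond the scatter) cyclopropylmethyl also stands clear of both hydrogen and cyclopentyl, so the small-ring result at this nitrogen is no longer confined to compound 3. No supporting measurement bears on why these numbers fall as they do.

Open, on these data alone, is how a longer straight alkyl chain, such as n-butyl, would read at this nitrogen. Also open, as far as these compounds go, is how a chain ending in an amine or a hydroxyl would read there.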